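Predicting a difluorophenyl analogue from one aminophenyl-to-dimethoxyphenyl step

This account rests on a few compounds, and the source may have more. Where it says the series, first, only, none or still open, it means among the compounds named here.

The study measures cytotoxicity in a functional assay on RXF 393 cells (Homo sapiens) for cytotoxicity, read by sulforhodamine B assay, with a stated time of 48 h, tested at 100 uM; a higher number here means a weaker effect of the compound at the concentration tested, a lower number a stronger effect. Compound 1, `COc1cc(-c2cc(/C=C/C(=O)c3ccc(N)cc3)[nH]n2)cc(OC)c1OC`, gives -86% in this assay, the highest of the two numbers recorded. For the measured compounds named here, its companion compound 2, `COc1ccc(C(=O)/C=C/c2cc(-c3cc(OC)c(OC)c(OC)c3)n[nH]2)cc1OC`, gives -98%, and the single step that separates them, a number 12 percentage points lower from compound 1 to compound 2 (beyond the scatter), is modest but beyond the scatter. The unmeasured compound 3, `COc1cc(-c2cc(/C=C/C(=O)c3ccc(F)c(F)c3)[nH]n2)cc(OC)c1OC`, differs from compound 1 as follows: 3,4-difluorophenyl in place of 4-aminophenyl on a carbonyl carbon. Going by the values given here, only the step from compound 1 to compound 2 bears on this change, since it too swaps the 4-aminophenyl on the carbonyl carbon for another six-membered aromatic ring, and it moved the number down by a modest amount. Compound 3 is therefore expected to show a step of about a number 5 percentage points lower from compound 1 to compound 3 (within the scatter) in this assay, downward or within the scatter. Compound 3 is estimated at -91%, with a range from -100% to -76%.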

Compound 3, a percentage reported as activity, at one concentration (the size of the read-out at that concentration, not a potency): -61%
Compound 3: middle estimate off by 30 percentage points, on the low side, outside the stated range (above it).
By their numbers in this assay, from the lowest: compound 2; then compound 1; then compound 3.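

In this assay, the group on this carbonyl carbon proved able to move the number in either direction: replacing 4-aminophenyl with 3,4-difluorophenyl gives a number 25 percentage points higher from compound 1 to compound 3 (beyond the scatter), opposite in direction to the change seen with 3,4-dimethoxyphenyl. Set against 3,4-dimethoxyphenyl, the 3,4-difluorophenyl group gives a number 37 percentage points higher from compound 2 to compound 3 (beyond the scatter), a large step, so exchanging one six-membered aromatic ring for another is not a neutral change at this position. No measured information is available to account for this difference in direction.

The compounds shown leave open whether a 4-fluorophenyl or an unsubstituted phenyl group on this carbonyl carbon would fall nearer to compound 3 or to compound 2. They also leave open whether a 4-methoxyphenyl group alone would follow compound 2.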